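The source may report more compounds than this note shows. Statements on the series, on what has been measured and on what is new or still open speak of the compounds shown alone.

Measured so far in an assay on CHO-K1 cells for displacement of a labelled ligand from melanin-concentrating hormone receptor 1 (Homo sapiens), read by scintillation proximity assay, with a stated time of 2 h; a lower number here means a stronger inhibitor, a higher number a weaker inhibitor:
compound 1 `Cc1nc(N2CCC(N3CCNC3=O)CC2)nc2ccc(NC(=O)/C=C/c3ccc(OC(F)(F)F)cc3)cc12` gives 66 nM
compound 2 `Cc1nc(N2CCC(O)(C3CC3)CC2)nc2ccc(NC(=O)/C=C/c3ccc(Cl)cc3Cl)cc12` gives 620 nM

Among these two numbers compound 1 stands lowest; compound 2 gives the higher number, and this gap lies beyond the usual scatter of repeated measurements. Compound 3 `Cc1nc(N2CCC(N3CCCC3=O)CC2)nc2ccc(NC(=O)/C=C/c3ccc(OC(F)(F)F)cc3)cc12` is not yet measured. It differs from compound 1 in one place: 2-oxopyrrolidin-1-yl in place of 2-oxoimidazolidin-1-yl on a saturated ring carbon. Among the measured compounds shown here, no measured pair shows this very change, so its effect has to be judged from what compound 1 alone shows. The change keeps the five-membered ring and the carbonyl but takes away the hydrogen-bond donor counted for the leaving group; a small shift toward a weaker inhibitor seems the more likely outcome, though a result within the scatter would not surprise. Compound 3 is therefore expected to give about 130 nM in this assay, with a range from 50 nM to 400 nM, which means an expected step of a 2.0-fold higher number from compound 1 to compound 3 (0.29 log units; within the scatter).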

Compound 3, half-maximal inhibitory concentration: 11 nM
For compound 3 the middle estimate is 12-fold (1.07 log units) above the measured one, and the stated range ends above it.
By their numbers in this assay, from the lowest: compound 3; then compound 1; then compound 2.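

In this assay the change from 2-oxoimidazolidin-1-yl to 2-oxopyrrolidin-1-yl on a saturated ring carbon gives a 6.0-fold lower number from compound 1 to compound 3 (0.78 log units; beyond the scatter), so this position responds clearly to a small edit, and the loss of the hydrogen-bond donor counted on the leaving group here goes with a stronger inhibitor rather than a weaker one. The two groups match in ring size, heavy-atom count and hydrogen-bond acceptor count, and they differ in that one ring nitrogen gives way to a carbon. No measurement at hand explains this step.

This single pair cannot show whether the ring itself is needed, or whether an open-chain acetamide or a simple amine would serve at the same carbon. It also leaves open how a larger ring, such as 2-oxopiperidin-1-yl, would compare.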